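The compounds below may be only part of what the source reports. "The series", "measured", "known", "first", "only" and "open" are said of these compounds alone.

Measured so far in a functional assay on HL-60 cells (Homo sapiens) for inhibition, read by luminescence, with a stated time of 72 h, tested at 5 uM (on this read-out lower numbers stand for less inhibition of growth and higher numbers for more inhibition of growth at the one concentration tested), for this series:
- compound 1 (`C=CS(=O)(=O)NC/C=C/c1cc(OC)cc(O)c1C(=O)OC(C)C`) gives 16.6%
- compound 2 (`C=CS(=O)(=O)NC/C=C/c1cc(OC)cc(O)c1C(=O)OCc1ccc(Br)cc1`) gives 8.1%
- compound 3 (`C=CS(=O)(=O)NC/C=C/c1cc(OC)cc(O)c1C(=O)OCC(C)c1ccccc1`) gives 9.5%

Compound 3 (9.5%) is not separated from the other two measured compounds, and no order can be read among the three. Its two steps are a number 7.1 percentage points lower from compound 1 to compound 3 (within the scatter) and a number 1.4 percentage points higher from compound 2 to compound 3 (within the scatter) on this small set.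

The next compound is compound 4 (`C=CS(=O)(=O)NC/C=C/c1cc(OC)cc(O)c1C(=O)OCc1ccc(F)cc1`), and the change is 4-fluorophenyl in place of 1-phenylethyl on a saturated chain carbon bound to an oxygen next to a carbonyl group in full. In words, this is 4-fluorophenyl in place of 1-phenylethyl on a saturated chain carbon bound to an oxygen next to a carbonyl group. The same difference also reads as 2-phenylpropyl to 4-fluorobenzyl.

All three measured steps fall at this same place and all stay within the scatter, the widest being a number 8.5 percentage points lower from compound 1 to compound 2 (within the scatter) on this read-out. For the measured compounds named here, compound 2 (8.1%) carries 4-bromobenzyl at this place, but no measured compound carries 4-fluorobenzyl.

On these steps, no change beyond the scatter is expected in this assay for this swap. The expected size is a number 0.5 percentage points higher from compound 3 to compound 4 (within the scatter) on present evidence. Compound 4 is estimated at 10% with an expected range of 1% to 21% in this series.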

Compound 4, percent growth inhibition at one concentration: 10.9%
Estimate against measurement, compound 4: 0.9 percentage points below; measured number inside the range.
By their numbers in this assay, from the lowest: compounds 2, 3, 4 and 1 (each within the scatter of the next).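

In this assay the swap to 4-fluorophenyl on a saturated chain carbon bound to an oxygen next to a carbonyl group gives a number 1.4 percentage points higher from compound 3 to compound 4 (within the scatter) and adds a second halogen comparison at this place, where fluoro in place of bromo on an aromatic carbon gives a number 2.8 percentage points higher from compound 2 to compound 4 (within the scatter) on the same benzyl frame. Against the smaller isopropyl group, 4-fluorobenzyl gives a number 5.7 percentage points lower from compound 1 to compound 4 (within the scatter) and thus joins 4-bromobenzyl and 2-phenylpropyl, so that every step among these four groups at this place stays within the scatter and neither the halogen nor the chain carrying the phenyl ring separates any pair on this read-out. Nothing available bears on why the numbers lie so close together.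

As far as these compounds go, all four compounds share the core of compound 1 and were read at a single concentration, so it remains open whether these groups would separate at another concentration or in a full concentration series. Also open, from the compounds shown here alone, is whether a group of a different kind on this oxygen, such as a chain ending in an amine or a carboxylic acid, or a change elsewhere on the shared core, would move the number beyond the scatter.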